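Swapping the aryl group on the carbonyl of compound 3

A few compounds are considered here, and "the series" means these few. Any claim that something is new, unique, unknown or untested is made for them only; others in the source may bear on it.

Measured compounds:
compound 1 `N=C(N)N/N=C/c1ccc(/C=C/C(=O)c2cccc(Br)c2)cc1`, 49.7%
compound 2 `Cc1ccc(C(=O)/C=C/c2ccc(/C=N/NC(=O)c3ccncc3)cc2)c(C)c1`, 58.5%
compound 3 `N=C(N)N/N=C/c1ccc(/C=C/C(=O)c2ccc(Cl)cc2)cc1`, 56.4%

All three were tested in a functional assay on the whole organism (Ear) for inhibition, with Mus musculus as the target, with a stated time of 30 min, at a dose of 100 mg/kg by the intraperitoneal route; a higher number here means more inhibition at the dose given (going by the name of the read-out), a lower number less inhibition. Compound 3, with the structure `N=C(N)N/N=C/c1ccc(/C=C/C(=O)c2ccc(Cl)cc2)cc1`, gives 56.4%, which places it second of the three numbers; compound 2 gives 58.5% and compound 1 gives 49.7%, and both of these lie within the scatter of compound 3, so no order among the three can be read from the data.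

Compound 4, not yet measured, has the structure `Cc1ccc(C(=O)/C=C/c2ccc(/C=N/NC(=N)N)cc2)c(C)c1`. The change from compound 3 is 2,4-dimethylphenyl in place of 4-chlorophenyl on a carbonyl carbon. Among the compounds with values here, the only measured step at that same carbonyl carbon is a number 6.7 percentage points higher from compound 1 to compound 3 (within the scatter), an aryl swap that stayed within the scatter. Compound 2 already carries the 2,4-dimethylphenyl group, though on a different core, and gives 58.5%. Within the data shown here, no measured step therefore points to a shift beyond the scatter, and compound 4 is expected to show about the same inhibition as compound 3, with an estimated step of a number 0.6 percentage points higher from compound 3 to compound 4 (within the scatter). The estimate for compound 4 is 57%, with a range from 45% to 69%.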

Compound 4, a percentage reported as inhibition, in the whole organism at one dose (the size of the read-out at that dose, not a potency): 64.2%
Estimate against measurement, compound 4: 7.2 percentage points below, within the range that was stated.
By their numbers in this assay, from the lowest: compounds 1, 3, 2 and 4 (each within the scatter of the next, the first and the last beyond it).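

Within the data shown here, putting 2,4-dimethylphenyl on the carbonyl carbon in place of 4-chlorophenyl gives a number 7.8 percentage points higher from compound 3 to compound 4 (within the scatter) and so does not separate these two aryl groups, but in place of 3-bromophenyl it gives a number 14.5 percentage points higher from compound 1 to compound 4 (beyond the scatter) and this is the first step at this position to pass the scatter, though only modestly. The change on the amine nitrogen, where the small group of compound 4 replaces the larger ring-bearing group of compound 2, gives a number 5.7 percentage points higher from compound 2 to compound 4 (within the scatter) and leaves those two groups unseparated as well. No measurement at hand gives a cause for any of these steps.

Every group shown on the carbonyl carbon is a substituted phenyl ring, so what a plain methyl group there would do remains open. Also open, from the compounds shown here alone, is how a methoxy group on that phenyl ring would compare with the methyl, chloro and bromo groups.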